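This account rests on a few compounds, and the source may have more. Where it says the series, first, only, none or still open, it means among the compounds named here.

Measured compounds in a functional assay on FM3A cells (Mus musculus) for antiproliferative activity, with a stated time of 48 h; a lower number here means a stronger inhibitor, a higher number a weaker inhibitor:
- compound 1, `C=C(Br)C(=O)Nc1ccc(C(=O)/C=C/c2ccccc2)cc1`, gives 690 nM
- compound 2, `C=C(Br)C(=O)Nc1ccc(C(=O)/C=C/c2ccccc2OC)cc1`, gives 370 nM
- compound 3, `COc1ccc(/C=C/C(=O)c2ccc(N)cc2)c(OC)c1`, gives 43000 nM

Compound 1 and compound 2 share a core and differ in one place, (methoxy in place of hydrogen on an aromatic carbon). The step is a 1.9-fold lower number from compound 1 to compound 2 (0.27 log units; within the scatter). Compound 3 has a different core; its difference from compound 1 is not broken down here. Compound 3 stands apart from the other two: its number is higher than that of compound 1 and higher than that of compound 2, and both of these gaps lie beyond the scatter.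

Compound 4, `COc1ccc(/C=C/C(=O)c2ccc(N)cc2)c(OC)c1OC`, is not yet measured. It differs from compound 3 by methoxy in place of hydrogen on an aromatic carbon. Going by the values given here, this is the same kind of change as the one from compound 1 to compound 2, and it occurs in two pairs of the series, but the surroundings differ: in the first pair the new group sits ortho to a large group, in the second ortho to two methoxy groups and meta to a large group.

Among the compounds with values here, the only guidance is the step from compound 1 to compound 2, which stayed within the scatter. On that basis the step from compound 3 to compound 4 in this assay is expected to be small, a 1.4-fold lower number from compound 3 to compound 4 (0.16 log units; within the scatter). Compound 4 is therefore estimated at 30000 nM, with a likely span from 8000 nM to 100000 nM.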

Compound 4, half-maximal inhibitory concentration: 29000 nM
Compound 4: the middle estimate sits 1.0-fold (0.01 log units) above what was measured, within the range that was stated.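

In this assay, methoxy in place of hydrogen on an aromatic carbon gives a 1.5-fold lower number from compound 3 to compound 4 (0.17 log units; within the scatter), and this step can be set beside the earlier one on the other core: the same change on two cores in this assay, a 1.9-fold lower number (0.27 log units; within the scatter) from compound 1 to compound 2 and a 1.5-fold lower number (0.17 log units; within the scatter) from compound 3 to compound 4, 1.3-fold (0.10 log units) apart, within the scatter of two such steps. The two pairs therefore agree in this one respect: on both cores the change gives a step that stays within the scatter, even though the new methoxy has different surroundings in each pair. This does not show that methoxy has a real effect on either core, and two pairs read in a single assay do not establish a rule for the series or show that the change would transfer to any further core.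

Still open, from the compounds shown here alone, is whether a hydroxyl, a fluorine or a longer chain such as ethoxy on the same aromatic carbon would give a step beyond the scatter, or whether it would stay as small as methoxy does here. No pair shown differs only in the amine of compound 3 against the bromine-bearing amide of compound 1, so the wide gap between these two series cannot yet be assigned to that group alone.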